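Smaller ring on the aromatic carbon: compound 4 expected

The source may hold more compounds than are shown below. What is called first, only, known or untested is meant among the compounds shown, and "the series" means these compounds.

For the measured compounds named here, compound 3 `C[C@H]1[C@H](NCc2cc(C3CCCCC3)cs2)C[C@H]2C[C@@H]1C2(C)C` gives 780 nM in an ADME assay on MDCK cells (Canis lupus familiaris) for cytotoxicity, read by microscopy, with a stated time of 48 h (on this read-out higher numbers stand for lower toxicity in this test and lower numbers for higher toxicity in this test), the lowest of the three numbers measured so far; compound 2 `C[C@H]1[C@H](NCc2cc(-c3ccccc3)cs2)C[C@H]2C[C@@H]1C2(C)C` gives 5000 nM and compound 1 `CCc1csc(CN[C@@H]2C[C@H]3C[C@@H]([C@H]2C)C3(C)C)c1` gives 25000 nM. The measured steps were a 5.0-fold lower number from compound 1 to compound 2 (0.70 log units; beyond the scatter), a 32-fold lower number from compound 1 to compound 3 (1.51 log units; beyond the scatter) and a 6.4-fold lower number from compound 2 to compound 3 (0.81 log units; beyond the scatter), each beyond the scatter and each lowering the number. Compound 4 `C[C@H]1[C@H](NCc2cc(C3CCCC3)cs2)C[C@H]2C[C@@H]1C2(C)C` differs from compound 3 in one place: cyclopentyl in place of cyclohexyl on an aromatic carbon. Going by the values given here, no measured step pairs cyclopentyl with cyclohexyl, so the guide is only that the group entering has fewer heavy atoms than the one leaving, and the measured steps lowered the number as groups grew. Compound 4 is therefore expected to show a modest rise, a 1.9-fold higher number from compound 3 to compound 4 (0.28 log units; within the scatter), and is estimated at 1500 nM, with a range from 600 nM to 4000 nM.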

Compound 4, minimum cytotoxic concentration: 1560 nM
For compound 4 the middle estimate is 1.0-fold (0.02 log units) below the measured one; measured number inside the range.
By their numbers in this assay, from the lowest: compounds 3 and 4 (each within the scatter of the next); then compound 2; then compound 1.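

In this assay, the two non-aromatic carbon rings at this position cannot be told apart, with a 2.0-fold higher number from compound 3 to compound 4 (0.30 log units; within the scatter). Cyclopentyl still separates from the other groups, with a 3.2-fold lower number from compound 2 to compound 4 (0.51 log units; beyond the scatter) and a 16-fold lower number from compound 1 to compound 4 (1.20 log units; beyond the scatter), so the lower numbers here extend to a second non-aromatic ring and do not depend on cyclohexyl alone. No evidence is available to explain these differences.

On these data alone, whether cyclopropyl or a piperidine ring would give a number like those of compound 3 and compound 4 remains open. So does where a longer chain such as butyl would fall relative to ethyl.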